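This account rests on a few compounds, and the source may have more. Where it says the series, first, only, none or still open, it means among the compounds named here.

Measured in an ADME assay on microsomes from liver (Homo sapiens) for metabolic stability, read by LC-MS, with NADPH named in the record, with a stated time of 60 min, tested at 1 uM, in the absence of a further agent; on this read-out lower numbers stand for a less stable compound and higher numbers for a more stable compound:
- compound 1 `COc1ccc(-c2c(C)nc3c(N4CC[C@@H](NC(=O)c5ccccc5)C4)cc(C)nn23)cc1OC`: > 95% (a limit)
- compound 2 `COc1ccc(-c2c(C)nc3c(N4CC[C@@H](NC(=O)OC5CCCCC5)C4)cc(C)nn23)cc1OC`: > 95% (a limit)
- compound 3 `COc1ccc(-c2c(C)nc3c(N4CC[C@@H](NS(=O)(=O)c5ccc(C#N)cc5)C4)cc(C)nn23)cc1OC`: > 95% (a limit)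

Compound 3 therefore stands at a limit, as do the two others: the limit of > 95% in this assay, at which 3 of the 3 values shown sit. Compound 4 `COc1ccc(-c2c(C)nc3c(N4CC[C@@H](NS(N)(=O)=O)C4)cc(C)nn23)cc1OC` has amino in place of 4-cyanophenyl on a sulfonyl sulfur. The closest measured changes are a step that the two limits leave unreadable from compound 1 to compound 3 and a step that the two limits leave unreadable from compound 2 to compound 3, since each swaps the group on the amine nitrogen, but neither size can be read. With so little to go on, the expected step is a number no higher from compound 3 to compound 4 (the limit leaves the size open), meaning no change in this assay beyond the scatter. For compound 4 the estimate is 95%, with an expected range from 82% to 100%.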

Compound 4, percent of the compound remaining: > 95%
Compound 4 gave a limit, no number; the forecaster's own chance of this, stated with the estimate: 60%; the middle value sits exactly at the limit.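

Compound 4 gives > 95%, which is a limit and not a number, and its steps from compound 1, compound 2 and compound 3 cannot be read: the limit of > 95% in this assay, at which 4 of the 4 values shown sit.

The compounds shown leave open whether the groups on the amine nitrogen differ at all in stability.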